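Aryl swaps at the amine-bound carbon of the series

The compounds below may be only part of what the source reports. "The series", "measured", "known", "first", "only" and "open" are said of these compounds alone.

Measured so far:
Compound 1 `Oc1ccc(CN[C@@H]2CO[C@H](C(c3ccc(F)cc3)c3ccc(F)cc3)C[C@H]2O)cc1F` gives 13.1 nM in an assay on striatum for inhibition of sodium-dependent dopamine transporter (Rattus norvegicus); on this read-out lower numbers stand for stronger inhibition and higher numbers for weaker inhibition.
Compound 2 `O[C@@H]1C[C@@H](C(c2ccc(F)cc2)c2ccc(F)cc2)OC[C@H]1NCc1ccc2c(c1)CCO2` gives 17 nM in this assay.

Compound 2 stands beside compound 1 as one of two numbers, and the step of a 1.3-fold higher number from compound 1 to compound 2 (0.11 log units; within the scatter) keeps the pair within the scatter of each other. Compound 3 `COc1ccc(CN[C@@H]2CO[C@H](C(c3ccc(F)cc3)c3ccc(F)cc3)C[C@H]2O)cn1` carries a group of 8 heavy atoms (6 carbon, 1 nitrogen, 1 oxygen; one six-membered aromatic ring with 1 hetero atom) in place of a group of 9 heavy atoms (8 carbon, 1 oxygen; one five-membered non-aromatic ring with 1 hetero atom, one six-membered aromatic ring of carbon only), on a saturated chain carbon bound to an amine nitrogen. For the measured compounds named here, only one measured step bears on this kind of change, the aryl swap a 1.3-fold higher number from compound 1 to compound 2 (0.11 log units; within the scatter), and it was flat. Two aryl groups of different shape thus gave indistinguishable numbers on this carbon, so a third aryl group is expected to do the same, with a step of a 1.2-fold higher number from compound 2 to compound 3 (0.07 log units; within the scatter) that is estimated to stay inside the scatter. For compound 3 the expected value in this assay is 20 nM, with a range from 7 nM to 60 nM.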

Compound 3, inhibition constant: 20.1 nM
For compound 3 the middle estimate is 1.0-fold (0.00 log units) below the measured one; low and high end bracket the measured number.
By their numbers in this assay, from the lowest: compounds 1, 2 and 3 (each within the scatter of the next).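

In this assay, the flat response on the saturated chain carbon bound to an amine nitrogen now extends to a third aryl group: a 1.2-fold higher number from compound 2 to compound 3 (0.07 log units; within the scatter) and a 1.5-fold higher number from compound 1 to compound 3 (0.19 log units; within the scatter) both stay within the scatter. What is new is that 6-methoxypyridin-3-yl brings a six-membered aromatic ring with 1 hetero atom, and it replaces 3-fluoro-4-hydroxyphenyl without any readable difference, so neither a carbon-only aromatic ring nor the hydroxyl and fluorine of that group is required among these three compounds. Nothing available gives a reason for this flatness.

Open, from the compounds shown here alone, is whether the flat response survives a non-aromatic group on this carbon, such as cyclohexyl, or a group carrying a carboxylic acid. The compounds shown also do not address changes in the shared core, such as an amide in place of the amine.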